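A few compounds are considered here, and "the series" means these few. Any claim that something is new, unique, unknown or untested is made for them only; others in the source may bear on it.

Measured so far in an ADME assay on HEK293 cells (Homo sapiens) for cytotoxicity, read by MTT assay, with a stated time of 48 h; a higher number here means a weaker inhibitor, a lower number a stronger inhibitor:
compound 1 `Cc1cc(NC(=O)c2cccc(C(F)(F)F)c2)ccc1NS(C)(=O)=O` gives 194000 nM
compound 2 `Cc1cc(NC(=O)c2cccc(C(F)(F)F)c2)ccc1NS(=O)(=O)C(F)(F)F` gives 131000 nM

For the measured compounds named here, on these two numbers compound 1 stands with the higher value, its only neighbour being compound 2, and the single measured step is a 1.5-fold lower number from compound 1 to compound 2 (0.17 log units; within the scatter), a change on the sulfonyl sulfur that stays within the scatter.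

Compound 3 `CS(=O)(=O)Nc1ccc(NC(=O)c2cccc(C(F)(F)F)c2)cc1Cl` differs from compound 1 by chloro in place of methyl on an aromatic carbon. Going by the values given here, no measured step touches this position of the shared core, so none bears directly on the change; the one step that exists only shows that a small exchange elsewhere left this assay unmoved beyond the scatter. Nothing in the measurements therefore supports a step in either direction beyond the scatter for compound 3.

For compound 3 the expected value in this assay is 180000 nM, with a range from 90000 nM to 360000 nM, which means an expected step of a 1.1-fold lower number from compound 1 to compound 3 (0.03 log units; within the scatter).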

Compound 3, half-maximal inhibitory concentration: > 250000 nM
Compound 3: a limit, no number; the forecaster's own chance of this, stated with the estimate: 20%; at least 1.3-fold (0.14 log units) between middle value and limit.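

In this assay, for the compounds shown here, chloro in place of methyl on this aromatic carbon, ortho to a methanesulfonamido group, gives an at least 1.2-fold higher number from compound 1 to compound 3 (0.11 log units; that floor lies within the scatter), the first reading for any change at this position of the shared core. Compound 3 gives > 250000 nM in this assay, which is a limit and not a number. The step therefore has only a floor, yet it does rule out a lower number for chloro here, something the sulfonyl change could not show, and the reading stops at the end of the range: the limit of > 250000 nM in this assay, at which 1 of the 3 values shown sits.

On these data alone, how far compound 3 lies past its limit stays open, so the true size of the step is unknown. Also open, as far as these compounds go, is whether an amine or a methoxy group on this aromatic carbon would give a number within the range of the assay.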